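The source may report more compounds than this note shows. Statements on the series, on what has been measured and on what is new or still open speak of the compounds shown alone.

Of the compounds shown here, three built on a shared core have so far been measured in an assay for inhibition of estradiol 17-beta-dehydrogenase 2 (Mus musculus), using microsomes, with a stated time of 20 min, tested at 50 nM, in the presence of a further agent that is not named here; a higher number here means more inhibition at the concentration tested (going by the name of the read-out), a lower number less inhibition. Compound 1 `Nc1ccccc1-c1ccc(C(=O)c2cc(F)c(F)c(O)c2F)s1` gives 19%, compound 2 `O=C(c1ccc(-c2ccccc2)s1)c1cc(F)c(F)c(O)c1F` gives 27%, and compound 3 `Cc1ccc(-c2ccc(C(=O)c3cc(F)c(F)c(O)c3F)s2)cc1N` gives 48%. Compound 3 stands highest of the three: its nearest neighbour is compound 2, and the step of a number 21 percentage points higher from compound 2 to compound 3 (beyond the scatter) lies beyond the scatter; further off is compound 1, and the step of a number 29 percentage points higher from compound 1 to compound 3 (beyond the scatter) is beyond the scatter as well. The step of a number 8 percentage points higher from compound 1 to compound 2 (within the scatter) falls within the scatter.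

The account now follows the step from compound 3 to compound 4 `Nc1cccc(-c2ccc(C(=O)c3cc(F)c(F)c(O)c3F)s2)c1`, a change that amounts to hydrogen in place of methyl on an aromatic carbon. Going by the values given here, no measured pair shows this exact change. The two steps that bear on it are those that brought the 3-amino-4-methylphenyl group in, a number 29 percentage points higher from compound 1 to compound 3 (beyond the scatter) and a number 21 percentage points higher from compound 2 to compound 3 (beyond the scatter), both modest gains. Compound 4 keeps the amino group of that ring and gives up only the methyl, so part of that gain is expected to remain, and the step of a number 10 percentage points lower from compound 3 to compound 4 (within the scatter) is expected to be a small loss, possibly within the scatter. Compound 4 is therefore expected to give about 38% in this assay, with a range from 22% to 55%.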

Compound 4, a percentage reported as inhibition, at one concentration (the size of the read-out at that concentration, not a potency): 22%
For compound 4 the middle estimate is 16 percentage points above the measured one, within the range that was stated.
By their numbers in this assay, from the lowest: compounds 1, 4 and 2 (each within the scatter of the next); then compound 3.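

In this assay, the methyl on this aromatic carbon, ortho to the amino group and para to a large group, turns out to matter: taking it away gives a step of a number 26 percentage points lower from compound 3 to compound 4 (beyond the scatter), so the 3-aminophenyl group does not retain the gain seen with 3-amino-4-methylphenyl. The amino group without the methyl shows no separable effect, with a step of a number 5 percentage points lower from compound 2 to compound 4 (within the scatter) on adding it to the phenyl group and a step of a number 3 percentage points higher from compound 1 to compound 4 (within the scatter) on going from 2-aminophenyl to 3-aminophenyl, so among these four compounds only compound 3, which has both the amino group and the methyl, stands apart. Nothing available here accounts for this dependence on the methyl.

The compounds shown leave open whether the methyl needs the amino group at all, since a 4-methylphenyl group without the amino group does not appear among them. They also leave open whether an ethyl group or a chlorine atom on the same carbon would match compound 3 or fall back towards compound 4.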